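Swapping the lactone-bearing chain for a dimethoxymethyl group

The compounds below may be only part of what the source reports. "The series", "measured", "known", "first", "only" and "open" are said of these compounds alone.

Of the compounds shown here, three have been measured in an assay on microsomes from liver for inhibition of sterol O-acyltransferase 1 (Rattus norvegicus); a lower number here means a stronger inhibitor, a higher number a weaker inhibitor. Compound 1 `C[C@]1(O)CC(=O)OC(CSc2nc(-c3ccccc3)c(-c3ccccc3)[nH]2)C1` gives 140 nM, the lowest of the three numbers. Compound 2 `Cc1ccc(-c2nc(SC[C@H]3C[C@@](C)(O)CC(=O)O3)[nH]c2-c2ccc(C)cc2)cc1.Cc1ccc(-c2nc(SC[C@H]3C[C@](C)(O)CC(=O)O3)[nH]c2-c2ccc(C)cc2)cc1` gives 170 nM, which lies within the scatter of compound 1. Compound 3 `Cn1c(SC[C@H]2C[C@@](C)(O)CC(=O)O2)nc(-c2ccccc2)c1-c1ccccc1.Cn1c(SC[C@H]2C[C@](C)(O)CC(=O)O2)nc(-c2ccccc2)c1-c1ccccc1` gives 2600 nM, a gap from compound 1 that lies beyond the scatter.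

Compound 4 `COC(CSc1nc(-c2ccccc2)c(-c2ccccc2)[nH]1)OC` has not yet been measured. Its difference from compound 1 is a group of 5 heavy atoms (3 carbon, 2 oxygen; no ring) in place of a group of 9 heavy atoms (6 carbon, 3 oxygen; one six-membered non-aromatic ring with 1 hetero atom), on a saturated chain carbon bound to a sulfur. The group that enters, dimethoxymethyl, carries no ring and no hydrogen-bond donor, whereas the group that leaves carries one six-membered non-aromatic ring with 1 hetero atom and 1 hydrogen-bond donor.

For the measured compounds named here, no step between measured compounds covers this change, so the expectation rests on the size of the group removed. The step of an 8.6-fold higher number from compound 1 to compound 4 (0.93 log units; beyond the scatter) is estimated to move toward a weaker inhibitor, beyond the scatter. Compound 4 is therefore expected to give about 1200 nM, within a range from 300 nM to 6000 nM.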

Compound 4, half-maximal inhibitory concentration: 580 nM
The estimate for compound 4 lay 2.1-fold (0.32 log units) above the measured number; the measured number falls inside the stated range.
By their numbers in this assay, from the lowest: compounds 1 and 2 (each within the scatter of the next); then compound 4; then compound 3.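

In this assay, replacing the ring-bearing group of compound 1 with dimethoxymethyl, on a saturated chain carbon bound to a sulfur, gives a 4.1-fold higher number from compound 1 to compound 4 (0.62 log units; beyond the scatter) and is the first change at this position among the compounds shown. Compound 4 carries neither the six-membered ring nor a hydrogen-bond donor in this group, yet it still gives a number in the same assay, so inhibition at this level needs neither feature, although the loss of the larger group as a whole goes with a weaker inhibitor. Nothing in the data given explains this difference.

Going by these compounds, the ring, its hydroxyl and the size of the group changed together, so their separate contributions remain open. On these data alone, whether a carboxylic acid, an open-chain hydroxyalkyl group or a simple ester at this place would come closer to compound 1 also remains open.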